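The compounds below may be only part of what the source reports. "The series", "measured", "known", "first", "only" and "open" are said of these compounds alone.

Compound 1 `O=C(O)c1cc(=O)c2cc(OCCCOc3ccccc3)ccc2o1` gives 3.3 ug/mL in a functional assay on ileum (Cavia porcellus) for antagonist activity, with a stated time of 30 s; on this read-out lower numbers stand for stronger inhibition and higher numbers for weaker inhibition. Compound 2 `O=C(O)c1cc(=O)c2cc(OCCCCCOc3ccccc3)ccc2o1` gives 3.3 ug/mL in this assay. Compound 3 `O=C(O)c1cc(=O)c2ccc(OCCCCCCCOc3ccccc3)cc2o1` gives 1.8 ug/mL in this assay.

Compound 3 and compound 1 have different cores, and the difference between the two cores is not broken down here. Within the core of compound 1, the change 2-phenoxyethyl in place of phenoxy on a saturated chain carbon, three bonds along the chain from an oxygen on an aromatic ring produced no change at the digits printed from compound 1 to compound 2 (within the scatter). Compound 4 `O=C(O)c1cc(=O)c2ccc(OCCCCCCCCCOc3ccccc3)cc2o1`, not yet measured, arises from compound 3 by 2-phenoxyethyl in place of phenoxy on a saturated chain carbon, seven bonds along the chain from an oxygen on an aromatic ring. This is the same kind of change, not the same one: in compound 2 the new group sits three bonds along the chain from an oxygen on an aromatic ring, in compound 4 seven bonds along. Because the earlier step of no change at the digits printed from compound 1 to compound 2 (within the scatter) stayed within the scatter, compound 4 is expected to show a step of no change at the digits printed from compound 3 to compound 4 (within the scatter). Compound 4 is therefore estimated at 1.8 ug/mL, plausibly between 0.9 ug/mL and 3.6 ug/mL.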

Compound 4, half-maximal inhibitory concentration: 1.8 ug/mL
Estimate against measurement, compound 4: no gap at the digits printed; the measured number falls inside the stated range.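

In this assay the step is no change at the digits printed from compound 3 to compound 4 (within the scatter) on the core of compound 3, the same reading as on the core of compound 1. Set side by side, the two steps do not differ: the same change on two cores in this assay, no change at the digits printed (within the scatter) from compound 1 to compound 2 and no change at the digits printed (within the scatter) from compound 3 to compound 4, 1.0-fold (0.00 log units) apart, within the scatter of two such steps. Among the compounds shown here, this shows the change carrying across these two cores with no step beyond the scatter, but it rests on only two pairs, with the change at a different place along the chain in each, and it does not show that other cores would behave alike.

The compounds shown leave open how a chain ending in an amine instead of phenoxy, or a longer chain than that of compound 4, would read in this assay. No pair shown differs in the core alone, so the effect of the core itself remains unread.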